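Ring-Closed Amide Against Rat Paw Swelling: An Estimate

The source may hold more compounds than are shown below. What is called first, only, known or untested is meant among the compounds shown, and "the series" means these compounds.

Measured so far, in a functional assay on the whole organism (strain Wistar) for inhibition, with Rattus norvegicus as the target, read by paw edema, with stated times of 30 min and 3 h, at a dose of 100 mg/kg by the oral route; on this read-out lower numbers stand for less inhibition and higher numbers for more inhibition at the one dose given (going by the name of the read-out):
compound 1, `CCCCOc1cc(C(N)=O)nn1-c1ccccc1`, gives 26.5%
compound 2, `C=CCNC(=O)c1cc(OCCCC)n(-c2ccccc2)n1`, gives 4.4%
compound 3, `CCCCOc1cc(C(=O)NC(C)C)nn1-c1ccccc1`, gives 15.8%

All three share one core and differ only at the amide nitrogen. Compound 3 stands second highest of the three numbers: compound 1 lies above it, since a number 10.7 percentage points lower from compound 1 to compound 3 (beyond the scatter), and compound 2 lies below it, since a number 11.4 percentage points higher from compound 2 to compound 3 (beyond the scatter). Compound 4, `CCCCOc1cc(C(=O)N2CCCCC2)nn1-c1ccccc1`, has not been measured. It differs from compound 3 in one place: piperidin-1-yl in place of isopropylamino on a carbonyl carbon.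

Among the measured compounds shown here, no measured pair shows exactly this change. For the measured compounds named here, the steps that bear on it are those that put a group on the amide nitrogen in place of hydrogen: a number 10.7 percentage points lower from compound 1 to compound 3 (beyond the scatter) and a number 22.1 percentage points lower from compound 1 to compound 2 (beyond the scatter). Both point the same way, with the larger group lowering more. Compound 4 carries the nitrogen fully inside a ring, so a drop beyond the scatter is expected, on the order of a number 7.8 percentage points lower from compound 3 to compound 4 (within the scatter). Compound 4 is therefore estimated at 8%, likely within 0% to 20%.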

Compound 4, a percentage reported as inhibition, in the whole organism at one dose (the size of the read-out at that dose, not a potency): 15.6%
Compound 4: middle estimate off by 7.6 percentage points, on the low side; the measured number falls inside the stated range.
By their numbers in this assay, from the lowest: compound 2; then compounds 4 and 3 (each within the scatter of the next); then compound 1.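

Among the compounds shown here, compound 4 is the first here without the amide hydrogen and with the nitrogen inside a ring, yet in this assay that change shows only a number 0.2 percentage points lower from compound 3 to compound 4 (within the scatter) in this comparison, so neither feature separates these two compounds. The unsubstituted amide still stands apart, with a number 10.9 percentage points lower from compound 1 to compound 4 (beyond the scatter) for piperidin-1-yl in place of amino, while a number 11.2 percentage points higher from compound 2 to compound 4 (beyond the scatter) for piperidin-1-yl in place of allylamino shows that the allyl compound, not the ring compound, holds the lowest number of the set. No measurement available explains these differences.

Going by these compounds, whether a smaller ring such as pyrrolidin-1-yl would match piperidin-1-yl remains open. So does whether morpholin-4-yl, with an oxygen in the ring, or open-chain dimethylamino would give a similar number.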